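Carboxymethyl on the Ring Nitrogen: From Compound 3 to Compound 4

This account rests on a few compounds, and the source may have more. Where it says the series, first, only, none or still open, it means among the compounds named here.

Compound 1, `CCOc1ccc2nc(Cl)c(/C=C3\SC(=S)NC3=O)cc2c1`: in a toxicity assay on PANC-1 cells (Homo sapiens) for cytotoxicity, read by MTT assay, with a stated time of 48 h (on this read-out higher numbers stand for weaker inhibition of growth and lower numbers for stronger inhibition of growth), compound 1 gives > 100 ug/mL, which is a limit of the assay rather than a number.
Compound 2, `COc1ccc2nc(Cl)c(/C=C3\SC(=S)NC3=O)cc2c1`: in this assay compound 2 gives > 100 ug/mL, also a limit.
Compound 3, `O=C1NC(=S)S/C1=C\c1cc2cc(F)ccc2nc1Cl`: in this assay compound 3 gives > 100 ug/mL, again a limit.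

All three measured compounds sit at the same limit (the limit of > 100 ug/mL in this assay, at which 3 of the 3 values shown sit), so compound 3 stands neither higher nor lower than the others as far as the numbers show. The three steps among them, a step that the two limits leave unreadable from compound 1 to compound 2, a step that the two limits leave unreadable from compound 1 to compound 3 and a step that the two limits leave unreadable from compound 2 to compound 3, are left unreadable in size by the limits at both ends.

Compound 4, `O=C(O)CN1C(=O)/C(=C/c2cc3cc(F)ccc3nc2Cl)SC1=S`, differs from compound 3 by carboxymethyl in place of hydrogen on an amide-type nitrogen in a ring. Within the data shown here, every measured step changes the group on the aromatic ring and none touches the ring nitrogen, so no measured step bears on this change, and its direction and size cannot be predicted from the data. The step from compound 3 to compound 4 is therefore expected to be small, a number no higher from compound 3 to compound 4 (the limit leaves the size open). Compound 4 is estimated at 100 ug/mL, within a range from 30 ug/mL to 300 ug/mL, with a real chance that only a limit is again reported.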

Compound 4, concentration for 50% growth inhibition: > 100 ug/mL
Compound 4: only a limit was reported; the forecaster's own chance of this, stated with the estimate: 60%; the middle value sits exactly at the limit.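

In this assay compound 4 gives > 100 ug/mL, which is a limit, so the step from compound 3 to compound 4 cannot be read in size or direction: the limit of > 100 ug/mL in this assay, at which 4 of the 4 values shown sit.

The compounds shown leave open whether carboxymethyl on the ring nitrogen, or any change on the aromatic ring, alters growth inhibition at all.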